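The source may report more compounds than this note shows. Statements on the series, on what has been measured and on what is new or still open speak of the compounds shown alone.

Measured in a physicochemical assay for solubility, read by nephelometry, measured as kinetic solubility, at pH 2.0; a higher number here means a more soluble compound, a lower number a less soluble compound:
compound 1 `CCOC(=O)C1=C(C)N/C(=C/c2cc(C)n(-c3ccc(Cl)cc3)c2C)C1=O` — 1.6 ug/mL
compound 2 `CCOC(=O)C1=C(C)N/C(=C/c2cc(C)n(-c3ccc(N(C)C)cc3)c2C)C1=O` — 12.5 ug/mL
compound 3 `CCOC(=O)C1=C(C)N/C(=C/c2cc(C)n(-c3ccc(SC)cc3)c2C)C1=O` — 3.1 ug/mL

Compound 3 gives the second highest of the three numbers; it sits within the scatter of compound 1 and below compound 2 (a 4.0-fold lower number from compound 2 to compound 3 (0.61 log units; beyond the scatter)). Compound 4 `CCOC(=O)C1=C(C)N/C(=C/c2cc(C)n(-c3ccncc3)c2C)C1=O` carries pyridin-4-yl in place of 4-(methylsulfanyl)phenyl on an aromatic nitrogen. For the measured compounds named here, two measured steps bear on this change: a 1.9-fold higher number from compound 1 to compound 3 (0.29 log units; within the scatter) and a 4.0-fold lower number from compound 2 to compound 3 (0.61 log units; beyond the scatter). Going by the values given here, both swap one substituent on the same aryl ring, whereas here the whole ring changes and a ring nitrogen enters; no measured pair covers that. Compound 2, whose dimethylamino group is the only other nitrogen on this ring, gives the highest number in this assay. The expected step, a 9.7-fold higher number from compound 3 to compound 4 (0.99 log units; beyond the scatter), is a modest rise beyond the scatter, with wide uncertainty. Compound 4 is estimated at 30 ug/mL, range 6 ug/mL to 150 ug/mL.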

Compound 4, solubility: 100 ug/mL
Estimate against measurement, compound 4: 3.3-fold (0.52 log units) below; the measured number falls inside the stated range.
By their numbers in this assay, from the lowest: compounds 1 and 3 (each within the scatter of the next); then compound 2; then compound 4.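

In this assay, exchanging the whole aryl group on the aromatic nitrogen gives a larger step (a 32-fold higher number from compound 3 to compound 4 (1.51 log units; beyond the scatter)) than any substituent swap on the phenyl ring. The step is also large from the 4-chlorophenyl group (a 63-fold higher number from compound 1 to compound 4 (1.80 log units; beyond the scatter)), and pyridin-4-yl still exceeds the highest phenyl example (an 8.0-fold higher number from compound 2 to compound 4 (0.90 log units; beyond the scatter)), leaving compound 4 highest of the four. No evidence available here accounts for these steps.

Whether the placement of the ring nitrogen matters remains open, since pyridin-3-yl and pyridin-2-yl do not appear among these compounds. A pyrimidinyl group or a morpholine on the phenyl ring would also test how far this trend extends.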